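The compounds below may be only part of what the source reports. "The series", "measured", "known", "first", "only" and "open" are said of these compounds alone.

Working notes on the series. In a functional assay on HeLa cells (Homo sapiens) for antiproliferative activity, read by MTT assay, with a stated time of 72 h (on this read-out lower numbers stand for stronger inhibition and higher numbers for weaker inhibition), compound 1 `COc1cc(-c2nc(N(C)C)sc2-c2ccc3ccccc3c2)cc(OC)c1OC` gives 1400 nM. Compound 2 `COc1cc(-c2nc(N(C)C)sc2-c2ccc(C(F)(F)F)cc2)cc(OC)c1OC` gives > 10000 nM, which is a limit of the assay and not a number, so compound 2 has no exact position on the scale.

Compound 3 `COc1cc(-c2nc(C)sc2-c2ccc(C(F)(F)F)cc2)cc(OC)c1OC` differs from compound 2 by methyl in place of dimethylamino on an aromatic carbon, next to the ring nitrogen and next to the ring sulfur: methyl in place of dimethylamino on an aromatic carbon. The 4-(trifluoromethyl)phenyl group stays unchanged.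

Going by the values given here, the only measured step is an at least 7.1-fold higher number from compound 1 to compound 2 (0.85 log units; beyond the scatter), with 4-(trifluoromethyl)phenyl in place of naphthalen-2-yl. Among the compounds with values here, that step changes a different place, so no measured step gives the size or direction of the present change. With only a limit as the starting point, no step beyond the scatter is expected in this assay, and a value near or past the limit is the likeliest outcome. The estimated step is a number no higher from compound 2 to compound 3 (the limit leaves the size open). The expected value for compound 3 is 10000 nM, with an estimated range of 3000 nM to 30000 nM.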

Compound 3, half-maximal inhibitory concentration: 3830 nM
The estimate for compound 3 lay 2.6-fold (0.42 log units) above the measured number, and the stated range covers the measured number.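

In this assay, this is the first change shown at the aromatic carbon next to the ring nitrogen and next to the ring sulfur, and methyl in place of dimethylamino gives an at least 2.6-fold lower number from compound 2 to compound 3 (0.41 log units; beyond the scatter), with the 4-(trifluoromethyl)phenyl group unchanged. The read-out therefore responds to this position, and with this aryl group the dimethylamino group is not needed to obtain a value inside the measurable range, as the pair of compound 2 and compound 3 shows. The printed step gives only the smallest possible size of the change, because compound 2 stands at a limit of the assay and not at a number: the limit of > 10000 nM in this assay, at which 1 of the 3 values shown sits.

The compounds shown leave open whether methyl in place of dimethylamino moves the read-out in the same direction when naphthalen-2-yl takes the place of 4-(trifluoromethyl)phenyl on the shared core. Going by these compounds alone, also open is how a hydrogen, an ethyl chain or a primary amine at this position would compare with methyl and dimethylamino, so the single pair gives no trend across groups at this carbon.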